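Fluoro on the phenylpiperazine: compound 3 to compound 4

The compounds below may be only part of what the source reports. "The series", "measured", "known", "first", "only" and "open" are said of these compounds alone.

Values in a functional assay on DU-145 cells (Homo sapiens) for cytotoxicity, read by sulforhodamine B assay, with a stated time of 48 h; a lower number here means that less compound is tolerated, a higher number that more compound is tolerated:
Compound 1, `N#Cc1ccc(Nc2nc(Oc3ccnc4ccccc34)nc(N3CCCCC3)n2)cc1C(F)(F)F`, sits at the limit > 100000 nM.
Compound 2, `COc1ccc(CN2CCN(c3nc(Nc4ccc(C#N)c(C(F)(F)F)c4)nc(Oc4ccnc5ccccc45)n3)CC2)c(OC)c1OC`, sits at the limit > 100000 nM.
Compound 3, `N#Cc1ccc(Nc2nc(Oc3ccnc4ccccc34)nc(N3CCN(c4ccccc4)CC3)n2)cc1C(F)(F)F`, sits at the limit > 100000 nM.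

Compound 3 therefore stands only at a limit of this assay, and the two further values shown are limits as well. The one step that joins two of these compounds in a single place, a step that the two limits leave unreadable from compound 1 to compound 3, cannot be read, because of the limit of > 100000 nM in this assay, at which 3 of the 3 values shown sit. Among the measured compounds shown here, no compound has yet given a number rather than a limit.

Compound 4, `N#Cc1ccc(Nc2nc(Oc3ccnc4ccccc34)nc(N3CCN(c4ccccc4F)CC3)n2)cc1C(F)(F)F`, differs from compound 3 by fluoro in place of hydrogen on an aromatic carbon. For the measured compounds named here, no measured step in this assay bears readably on that change, since the only step available, from a piperidin-1-yl to a 4-phenylpiperazin-1-yl on the shared core, runs between two limits. The expectation for compound 4 is therefore that the step that the limit leaves unreadable from compound 3 to compound 4 lies within the scatter, and that this assay most likely again reports a limit. The estimate for compound 4 is 150000 nM, with a range from 50000 nM to 500000 nM.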

Compound 4, concentration lethal to 50% of the cells: > 100000 nM
Compound 4: a limit, no number; the forecaster's own chance of this, stated with the estimate: 80%; the middle value is on the limit's open side.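

In this assay no size can be given for the step from compound 3 to compound 4, phenyl to 2-fluorophenyl, because both compounds stand at a limit: the limit of > 100000 nM in this assay, at which 4 of the 4 values shown sit.

The compounds shown leave open whether any change on the shared core gives a number rather than a limit in this assay.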